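Oxazolone carbamates as acid ceramidase inhibitors: a substituent swap

This account rests on a few compounds, and the source may have more. Where it says the series, first, only, none or still open, it means among the compounds named here.

Of the compounds shown here, three have been measured in an assay on HEK293 cells for inhibition of acid ceramidase (Homo sapiens), with a stated time of 10 min; on this read-out higher numbers stand for weaker inhibition and lower numbers for stronger inhibition. Compound 1 `COc1ccc(-c2ccc3c(c2)oc(=O)n3C(=O)NCCCCc2ccccc2)cc1` gives 67 nM. Compound 2 `O=C(NCCCCc1ccccc1)n1c(=O)oc2cc(F)ccc21` gives 31 nM, and compound 3 `O=C(NCCCCc1ccccc1)n1c(=O)oc2ccc(F)cc21` gives 12 nM, the lowest number of the three. The difference between the cores of compound 2 and compound 3 is not broken down here; they share the same atoms, joined differently.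

Between compound 2 and compound 1 one change is made: 4-methoxyphenyl in place of fluoro on an aromatic carbon. This change produces a 2.2-fold higher number from compound 2 to compound 1 (0.33 log units; beyond the scatter).

Compound 4 `COc1ccc(-c2ccc3oc(=O)n(C(=O)NCCCCc4ccccc4)c3c2)cc1` is not yet measured. It arises from compound 3 by the same change, (4-methoxyphenyl in place of fluoro on an aromatic carbon), and the place described for it matches the place described between compound 2 and compound 1 word for word.

Among the compounds with values here, because the only measured instance of this change, a 2.2-fold higher number from compound 2 to compound 1 (0.33 log units; beyond the scatter), is modest, the step from compound 3 to compound 4 in this assay is expected to be of similar size, a 2.2-fold higher number from compound 3 to compound 4 (0.34 log units; beyond the scatter). With one precedent only, the expectation carries a wide range. Compound 4 is therefore estimated at 26 nM in this assay, between 10 nM and 70 nM.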

Compound 4, half-maximal inhibitory concentration: 67 nM
For compound 4 the middle estimate is 2.6-fold (0.41 log units) below the measured one, within the range that was stated.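

In this assay, 4-methoxyphenyl in place of fluoro gives a 5.6-fold higher number from compound 3 to compound 4 (0.75 log units; beyond the scatter), so the change moves the number in the same direction on both cores, towards weaker inhibition. Set beside the earlier step, the new step cannot be told apart from it in size: the same change on two cores in this assay, a 2.2-fold higher number (0.33 log units; beyond the scatter) from compound 2 to compound 1 and a 5.6-fold higher number (0.75 log units; beyond the scatter) from compound 3 to compound 4, 2.6-fold (0.41 log units) apart, within the scatter of two such steps This shows that, for these two cores, the change behaves alike within the limits of the measurements, but with only two instances, on cores that share the same atoms joined differently, it does not show that the step would carry over to any other core, nor does it explain why the change weakens inhibition.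

The compounds shown leave open how other groups would behave on this aromatic carbon, for example an amine, a carboxylic acid or an unsubstituted phenyl. They also leave open whether the step would keep its direction and size with a longer chain in place of the one ending in phenyl.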